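The source may report more compounds than this note shows. Statements on the series, on what has been measured and on what is new or still open speak of the compounds shown alone.

Measured in a physicochemical assay for solubility, with a stated time of 18 h, at pH 7.4; a lower number here means a less soluble compound, a higher number a more soluble compound:
compound 1 `Fc1ccc(-c2ccc3c(NCCCNCc4ccco4)ccnc3c2)cc1` — 32000 nM
compound 2 `Fc1ccc(Oc2ccc3c(NCCCNCc4ccco4)ccnc3c2)cc1` — 14500 nM
compound 3 `Clc1ccc(Oc2ccc3c(NCCCNCc4ccco4)ccnc3c2)cc1` — 14500 nM

Compound 3 sits level with compound 2 at the digits reported, the two together forming the low end of the three numbers; the only separation beyond the scatter is a 2.2-fold lower number from compound 1 to compound 3 (0.34 log units; beyond the scatter), matched by a 2.2-fold lower number from compound 1 to compound 2 (0.34 log units; beyond the scatter). The step of no change at the digits printed from compound 2 to compound 3 (within the scatter) shows the halogen swap on the phenoxy ring to be without effect in this assay.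

Compound 4 `c1coc(CNCCCNc2ccnc3cc(-c4cccc5ccccc45)ccc23)c1` differs from compound 3 by naphthalen-1-yl in place of 4-chlorophenoxy on an aromatic carbon. For the measured compounds named here, the one measured step that bears on it is a 2.2-fold lower number from compound 1 to compound 3 (0.34 log units; beyond the scatter), the only case here where a directly attached aryl ring and an aryloxy ring are compared, and it is modest. Going by the values given here, compound 4 carries a directly attached ring, as compound 1 does, but a larger one with no acceptor, for which no measured step exists. The expectation is therefore a step of about a 1.0-fold higher number from compound 3 to compound 4 (0.01 log units; within the scatter), with the range held wide; compound 4 is estimated at 15000 nM (range 5000 nM to 45000 nM).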

Compound 4, solubility: 32000 nM
Estimate against measurement, compound 4: 2.1-fold (0.33 log units) below; low and high end bracket the measured number.
By their numbers in this assay, from the lowest: compounds 2 and 3 (each within the scatter of the next); then compounds 1 and 4 (each within the scatter of the next).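

In this assay this position takes a directly attached naphthalen-1-yl in place of 4-fluorophenyl with no change at the digits printed from compound 1 to compound 4 (within the scatter) as the whole of the step, so the second fused aromatic ring leaves the number level with compound 1. Against the phenoxy compounds the same group gives a 2.2-fold higher number from compound 3 to compound 4 (0.34 log units; beyond the scatter) and a 2.2-fold higher number from compound 2 to compound 4 (0.34 log units; beyond the scatter) and both steps are modest. Across these four compounds the numbers therefore fall into two pairs, with the directly attached rings of compounds 1 and 4 on one side and the oxygen-linked rings of compounds 2 and 3 on the other, and no compound goes against this split.

Going by these compounds, whether the split would hold for a benzyloxy group, a morpholine or a carboxylic acid-bearing phenyl at this position remains open. No supporting data are available to account for these steps.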